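Methoxy for Methyl: Estimating Compound 4

The source may hold more compounds than are shown below. What is called first, only, known or untested is meant among the compounds shown, and "the series" means these compounds.

Three compounds have been measured in a functional assay on MCF7 cells (Homo sapiens) for inhibition, read by MTT assay, with a stated time of 72 h; a higher number here means a weaker inhibitor, a lower number a stronger inhibitor:
compound 1, `COc1ccccc1Nc1nc(SCc2cn(Cc3ccccc3Cl)nn2)nc(-c2ccccc2)c1C#N`, gives 6170 nM
compound 2, `Cc1ccccc1Nc1nc(SCc2cn(Cc3ccccc3Cl)nn2)nc(-c2ccccc2)c1C#N`, gives 7950 nM
compound 3, `Cc1ccc(Nc2nc(SCc3cn(Cc4ccccc4Cl)nn3)nc(-c3ccc(C(C)C)cc3)c2C#N)cc1`, gives 12200 nM

All three numbers lie within the usual scatter of one another, so no order among them can be read. Compound 2 and compound 3 differ in their cores; that difference is not broken down here. Compound 1 differs from compound 2 only by methoxy in place of methyl on an aromatic carbon, and the measured step was a 1.3-fold lower number from compound 2 to compound 1 (0.11 log units; within the scatter).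

Compound 4, `COc1ccc(Nc2nc(SCc3cn(Cc4ccccc4Cl)nn3)nc(-c3ccc(C(C)C)cc3)c2C#N)cc1`, has not yet been measured. It differs from compound 3 by methoxy in place of methyl on an aromatic carbon. Among the measured compounds shown here, this is the same kind of change as the one between compound 2 and compound 1, not the same one: in compound 1 the methoxy sits ortho to a large group, in compound 4 para to a large group.

Because the step of a 1.3-fold lower number from compound 2 to compound 1 (0.11 log units; within the scatter) stayed within the scatter, the step from compound 3 to compound 4 is expected to be similarly small, a 1.3-fold lower number from compound 3 to compound 4 (0.11 log units; within the scatter). Compound 4 is therefore estimated at 9500 nM in this assay, with a likely range from 4000 nM to 22000 nM.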

Compound 4, half-maximal inhibitory concentration: 10300 nM
Beside the measured number, compound 4's estimate is 1.1-fold (0.04 log units) below it; the range from low to high includes it.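

In this assay, methoxy in place of methyl on the second core gives a small step, a 1.2-fold lower number from compound 3 to compound 4 (0.07 log units; within the scatter), and it agrees with the step seen on the first core: the same change on two cores in this assay, a 1.3-fold lower number (0.11 log units; within the scatter) from compound 2 to compound 1 and a 1.2-fold lower number (0.07 log units; within the scatter) from compound 3 to compound 4, 1.1-fold (0.04 log units) apart, within the scatter of two such steps.

On these two cores, then, the change carries over in the plain sense that the number stays within the usual scatter both times. Among the compounds shown here, this does not show that the change has no effect in the wider series: there are only two pairs, each step is too small to be told from noise, and the methoxy in compound 4 sits para to a large group, a different setting from the one in compound 1.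

The compounds shown leave open whether a group other than methyl or methoxy at this place, such as a hydroxyl, an amine or a carboxylic acid, would move the number beyond the scatter. They also leave open whether a longer chain, such as ethoxy, would do so.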